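Acetylation of the diol side chain: cytotoxicity outlook

The compounds below may be only part of what the source reports. "The series", "measured", "known", "first", "only" and "open" are said of these compounds alone.

Compound 1 `COC(=O)c1cc(-c2ccccc2)cc(OC)c1C` and compound 2 `C/C(=C/[C@H](O)[C@H](O)c1ccccc1)CCO` were run in an ADME assay on Vero cells (Chlorocebus sabaeus) for cytotoxicity, read by fluorescence; a higher number here means a weaker inhibitor, a lower number a stronger inhibitor. In this assay compound 1 gives 74000 nM. For compound 2 this assay returns only a limit, > 225000 nM, as noted in the limit of > 225000 nM in this assay, at which 1 of the 2 values shown sits. Compound 3 `CC(=O)OCC/C(C)=C\[C@H](O)[C@H](O)c1ccccc1` is not yet measured; it differs from compound 2 by acetyl in place of hydrogen on an oxygen on a saturated carbon. For the measured compounds named here, no measured step of this kind exists here, so the step is expected to stay within the scatter, with an at least 1.1-fold lower number from compound 2 to compound 3 (0.05 log units; that floor lies within the scatter) as the expected shift. Compound 3 is estimated at 200000 nM, within 60000 nM to 400000 nM.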

Compound 3, half-maximal inhibitory concentration: > 189000 nM
Compound 3 gave a limit, no number (the forecaster's own chance of this, stated with the estimate: 60%); the middle value is on the limit's open side.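

For the compounds shown here, compound 2 and compound 3 each give only a limit, so no step between them can be read in this assay. Going by these compounds, whether acetyl in place of hydrogen on this oxygen changes the read-out remains open.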